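Adding a Nitrile to the Methoxy Compound

The source may report more compounds than this note shows. Statements on the series, on what has been measured and on what is new or still open speak of the compounds shown alone.

Measured compounds:
Compound 1 `COc1ccc(Br)c(-c2nc3ncccc3o2)c1` – 8%
Compound 2 `COc1cccc(-c2nc3ncccc3o2)c1` – 14%
Compound 3 `N#Cc1cccc(-c2nc3ncccc3o2)c1` – 21%

In a functional assay on the whole organism for inhibition, with Rattus norvegicus as the target, at a dose of 30 mg/kg (a higher number here means more inhibition at the dose given (going by the name of the read-out), a lower number less inhibition), compound 2 gives 14%, which stands second highest of the three numbers; its nearest neighbour is compound 1 at 8%, and the furthest is compound 3 at 21%, both within the scatter. Compound 4 `COc1ccc(C#N)c(-c2nc3ncccc3o2)c1` has not yet been measured. It differs from compound 2 by one change: cyano in place of hydrogen on an aromatic carbon. Within the data shown here, two measured steps bear on it. The step of a number 6 percentage points higher from compound 1 to compound 2 (within the scatter) shows that removing a halogen from the ring of compound 1 moves the number by little, and the step of a number 7 percentage points higher from compound 2 to compound 3 (within the scatter) shows that exchanging methoxy for cyano on the ring of compound 2 also stays within the scatter. Since both steps are small, compound 4 is expected to show a step of a number 4 percentage points higher from compound 2 to compound 4 (within the scatter), that is, nothing beyond the scatter. Compound 4 is therefore estimated at 18%, with a range from 5% to 32%.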

Compound 4, a percentage reported as inhibition, in the whole organism at one dose (the size of the read-out at that dose, not a potency): 3%
Estimate against measurement, compound 4: 15 percentage points above; measured number outside the range, below it.
By their numbers in this assay, from the lowest: compounds 4, 1, 2 and 3 (each within the scatter of the next, the first and the last beyond it).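

In this assay, among these compounds, cyano on the aromatic carbon ortho to a group of 9 heavy atoms and para to a methoxy group gives a number 11 percentage points lower from compound 2 to compound 4 (beyond the scatter), the first step to lie beyond the scatter. Bromo and cyano at this same position are not told apart, with a number 5 percentage points lower from compound 1 to compound 4 (within the scatter), so of the pairs compared here only hydrogen and cyano separate. No measurement shown accounts for the step from hydrogen to cyano.

Going by these compounds, it remains open how an amine or a carboxylic acid at this position would read in this assay, and whether any such group would carry the number clear of compound 2. On these data alone, it is also open whether cyano here would give the same step if a longer chain took the place of the methoxy group.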